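The compounds below may be only part of what the source reports. "The series", "measured", "known", "first", "only" and "open" are said of these compounds alone.

Measured compounds:
Compound 1 `CNC(=O)[C@@]12C[C@@H]1[C@@H](n1cnc3c(NC)nc(C#Cc4ccc(CO)cc4)nc31)[C@H](O)[C@@H]2O` — 16%
Compound 2 `CNC(=O)[C@@]12C[C@@H]1[C@@H](n1cnc3c(NC)nc(C#Cc4nccs4)nc31)[C@H](O)[C@@H]2O` — 31%

In an assay on CHO cells for displacement of a labelled ligand from adenosine receptor A1 (Homo sapiens), read by scintillation counting, with a stated time of 60 min, tested at 10 uM (a lower number here means less inhibition, a higher number more inhibition at the concentration tested (going by the name of the read-out)), compound 1 gives 16%. For the measured compounds named here, compound 2 gives 31% in this assay, the highest of the two numbers; the single step of a number 15 percentage points higher from compound 1 to compound 2 (beyond the scatter) is beyond the scatter and modest in size. Compound 3 `CNC(=O)[C@@]12C[C@@H]1[C@@H](n1cnc3c(NC)nc(C#CC4CCCCC4)nc31)[C@H](O)[C@@H]2O` is not yet measured in this assay.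

The change from compound 2 to compound 3 is cyclohexyl in place of 1,3-thiazol-2-yl on a triple-bonded carbon. It keeps the shared core and alters only the group on the triple-bonded carbon. Going by the values given here, the one measured step, a number 15 percentage points higher from compound 1 to compound 2 (beyond the scatter), sits at the same place, but it exchanged one aromatic group for another, whereas here an aromatic ring with two hetero atoms gives way to a six-membered non-aromatic ring of carbon only. Among the compounds with values here, no measured pair shows what that exchange does. The expected step is therefore a number 6 percentage points lower from compound 2 to compound 3 (within the scatter), and its direction is uncertain, so a step of either sign, or none beyond the scatter, remains possible. Compound 3 is estimated at 25%, within a range from 5% to 50%.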

Compound 3, a percentage reported as inhibition, at one concentration (the size of the read-out at that concentration, not a potency): 15%
Compound 3: the middle estimate sits 10 percentage points above what was measured, within the range that was stated.
By their numbers in this assay, from the lowest: compounds 3 and 1 (each within the scatter of the next); then compound 2.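

In this assay, for the compounds shown here, the place on the triple-bonded carbon now carries a non-aromatic ring for the first time, and cyclohexyl in place of 1,3-thiazol-2-yl gives a number 16 percentage points lower from compound 2 to compound 3 (beyond the scatter) in this comparison, so this exchange moves the number beyond the scatter. Cyclohexyl in place of 4-(hydroxymethyl)phenyl gives a number 1 percentage points lower from compound 1 to compound 3 (within the scatter) and thus leaves these two quite different groups indistinguishable in this read-out. Among these three compounds, an aromatic ring at this place does not by itself go with the higher number, since compound 1 also carries one yet stays level with compound 3, and only the 1,3-thiazol-2-yl group of compound 2 stands apart.

Going by these compounds, it remains open whether an unsubstituted phenyl, a 2-pyridyl or an open chain such as n-butyl on the same triple-bonded carbon would follow compound 2 or stay with compound 1 and compound 3, and whether any of them would exceed compound 2. Nothing among the data shown explains why the 1,3-thiazol-2-yl group stands apart.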